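This account rests on a few compounds, and the source may have more. Where it says the series, first, only, none or still open, it means among the compounds named here.

Compound 3 `COc1cc2ncnc(NCc3cccc(NC(=O)Nc4ccc(F)cc4)c3)c2cc1OC` was measured in a functional assay on A549 cells (Homo sapiens) for antiproliferative activity, read by MTT assay (a higher number here means a weaker inhibitor, a lower number a stronger inhibitor), and gives 16900 nM. Among the three measured compounds it stands second highest on this number. Its nearest neighbour is compound 2 `COc1ccccc1NC(=O)Nc1cccc(CNc2ncnc3cc(OC)c(OC)cc23)c1`, which in this assay gives 15200 nM; the step of a 1.1-fold higher number from compound 2 to compound 3 (0.05 log units; within the scatter). The furthest is compound 1 `COc1cc2ncnc(NCc3cccc(NC(=O)Nc4ccccc4C)c3)c2cc1OC`, which gives 21400 nM; the step of a 1.3-fold lower number from compound 1 to compound 3 (0.10 log units; within the scatter). The remaining pair shows a 1.4-fold lower number from compound 1 to compound 2 (0.15 log units; within the scatter).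

Compound 4 `COc1cc2ncnc(NCc3cccc(NC(=O)Nc4ccc(Cl)cc4)c3)c2cc1OC` differs from compound 3 in one place: chloro in place of fluoro on an aromatic carbon.

Within the data shown here, the steps that bear on this change are the two in which the aryl group on the urea nitrogen was altered, from compound 1 to compound 3 and from compound 2 to compound 3; both were within the scatter. Among the measured compounds shown here, no measured step exchanges fluoro for chloro directly. On that basis compound 4 is expected to show no shift beyond the scatter in this assay, that is a 1.2-fold lower number from compound 3 to compound 4 (0.08 log units; within the scatter). The estimate for compound 4 in this assay is 14000 nM, with a range from 5000 nM to 40000 nM.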

Compound 4, half-maximal inhibitory concentration: 30400 nM
Compound 4: the middle estimate sits 2.2-fold (0.34 log units) below what was measured; the measured number falls inside the stated range.
By their numbers in this assay, from the lowest: compounds 2, 3, 1 and 4 (each within the scatter of the next).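

In this assay, among these compounds, the first exchange of one halogen for another on this aromatic carbon, para to a large group, gives a 1.8-fold higher number from compound 3 to compound 4 (0.25 log units; within the scatter) and so stays short of a shift beyond the scatter. With 4-chlorophenyl on the amide-type nitrogen, the step from the 2-methoxyphenyl group is a 2.0-fold higher number from compound 2 to compound 4 (0.30 log units; within the scatter) and the step from the 2-methylphenyl group is a 1.4-fold higher number from compound 1 to compound 4 (0.15 log units; within the scatter); all four aryl groups therefore remain within the scatter of their listed neighbours on this nitrogen. No measurement here offers an explanation for these numbers.

The compounds shown leave open whether a nitrile or a carboxylic acid on this aromatic carbon would produce a step beyond the scatter. They also leave open whether a longer chain in place of the halogen would do so.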